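This account rests on a few compounds, and the source may have more. Where it says the series, first, only, none or still open, it means among the compounds named here.

Within the data shown here, compound 2 `Cc1c(OCCCCOc2ccc(C(=O)O)c(Cl)c2)ccc(C(=O)CC2CCCC2)c1O` is one of two compounds measured so far in an assay on HEK293 cells for positive allosteric modulation of metabotropic glutamate receptor 3 (Rattus norvegicus), read by thallium flux, with a stated time of 2.5 min; on this read-out higher numbers stand for an effect only at larger amounts of compound and lower numbers for an effect already at smaller amounts. In this assay, among the measured compounds shown here, compound 2 gives 2250 nM, and the only other measured compound, compound 1 `Cc1c(OCCCCOCOc2ccc(C(=O)O)cc2)ccc(C(=O)CC2CCCC2)c1O`, gives 1910 nM. Compound 2 therefore stands beside a single neighbour, and the two numbers lie within the usual scatter of each other, as the step of a 1.2-fold higher number from compound 1 to compound 2 (0.07 log units; within the scatter) shows.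

The unmeasured compound 3 `Cc1c(OCCCCOc2ccc(F)c(C(=O)O)c2)ccc(C(=O)CC2CCCC2)c1O` differs from compound 2 in one place: 3-carboxy-4-fluorophenyl in place of 4-carboxy-3-chlorophenyl on an oxygen on a saturated carbon. For the measured compounds named here, the only measured step that bears on this is the one from compound 1 to compound 2, which also replaced the group on an oxygen on a saturated carbon, and it was small, at a 1.2-fold higher number from compound 1 to compound 2 (0.07 log units; within the scatter). Exchanging one carboxy-substituted phenyl for another with a different halogen has thus not so far moved the number beyond the scatter. On this basis no step beyond the scatter is expected for compound 3, and the estimated step of a 1.0-fold lower number from compound 2 to compound 3 (0.01 log units; within the scatter) is small. Compound 3 is expected to give about 2200 nM in this assay, with a range from 1000 nM to 5000 nM.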

Compound 3, half-maximal effective concentration: 2490 nM
For compound 3 the middle estimate is 1.1-fold (0.05 log units) below the measured one; low and high end bracket the measured number.
By their numbers in this assay, from the lowest: compounds 1, 2 and 3 (each within the scatter of the next).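

In this assay, replacing the 4-carboxy-3-chlorophenyl of compound 2 with 3-carboxy-4-fluorophenyl gives a 1.1-fold higher number from compound 2 to compound 3 (0.04 log units; within the scatter), so changing both the halogen and the numbered ring place of the carboxy group, as the two names show, leaves the number within the scatter. Set against the (4-carboxyphenoxy)methyl group of compound 1, the same group gives a 1.3-fold higher number from compound 1 to compound 3 (0.12 log units; within the scatter), so the three groups on this oxygen on a saturated carbon cannot be told apart in this assay. No independent measurement is available to explain why these changes leave the number so flat.

From the compounds shown here alone, compound 3 differs from compound 2 in both the halogen and the numbering of the carboxy group, so the contribution of each change on its own remains unknown. All three compounds also carry a carboxylic acid, which leaves open what a tetrazole or a primary amide in its place would do to the number, and whether this flat picture would hold at all without that acid.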